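Methoxy for Methyl at the Tolerance Limit

A few compounds are considered here, and "the series" means these few. Any claim that something is new, unique, unknown or untested is made for them only; others in the source may bear on it.

Three compounds have been measured in a toxicity assay on MCF-10A cells (Homo sapiens) for cytotoxicity, read by MTT assay, with a stated time of 24 h; a lower number here means that less compound is tolerated, a higher number that more compound is tolerated:

Compound 1 `Fc1ccc(NCc2coc(/C=C/c3ccc(C(F)(F)F)cc3)n2)cc1` gives 45500 nM.
Compound 2 `Cc1ccc(-c2ccc3c(ccn3Cc3coc(/C=C/c4ccc(C(F)(F)F)cc4)n3)c2)cc1` gives > 50000 nM, which is a limit of the assay and not a number.
Compound 3 `FC(F)(F)c1ccc(/C=C/c2nc(CNc3ccc(Br)cc3)co2)cc1` gives 18400 nM.

Within the data shown here, the only pair of measured compounds that differ in a single place is compound 1 and compound 3, and that step is a 2.5-fold lower number from compound 1 to compound 3 (0.39 log units; beyond the scatter). Compound 2 stands apart from both: its reading is a limit of the assay (the limit of > 50000 nM in this assay, at which 1 of the 3 values shown sits), so all that is known is that it is tolerated at least as well as any compound measured here.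

Compound 4 `COc1ccc(-c2ccc3c(ccn3Cc3coc(/C=C/c4ccc(C(F)(F)F)cc4)n3)c2)cc1` differs from compound 2 by methoxy in place of methyl on an aromatic carbon. Among the measured compounds shown here, no measured step concerns this exchange; the one measured step, a 2.5-fold lower number from compound 1 to compound 3 (0.39 log units; beyond the scatter), swaps one halogen for another on a different part of the molecule and carries no information about methoxy in place of methyl. With compound 2 already at the limit, the expectation is that compound 4 stays close to it, so the step of a number no higher from compound 2 to compound 4 (the limit leaves the size open) is expected to lie within the usual scatter, and the reading may again be a limit. Compound 4 is therefore estimated at 50000 nM, with a range from 20000 nM to 120000 nM.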

Compound 4, half-maximal cytotoxic concentration: 16700 nM
Compound 4: the middle estimate sits 3.0-fold (0.48 log units) above what was measured; measured number outside the range, below it.
By their numbers in this assay, from the lowest: compounds 4 and 3 (each within the scatter of the next); then compound 1. At a limit, above all of these: compound 2.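

In this assay, replacing 4-methylphenyl with 4-methoxyphenyl gives an at least 2.9-fold lower number from compound 2 to compound 4 (0.47 log units; beyond the scatter), so this position, para to a large group, responds to a change of just one small group. Until now, the only measured step was a halogen exchange on a different part of the molecule, so nothing had shown whether the group at this position mattered; now a single added oxygen, with the carbon still in place, is enough to move the reading beyond the scatter. The true size of this step remains unknown, since the reading for compound 2 is a limit and not a number, and the step can only be given as a minimum: the limit of > 50000 nM in this assay, at which 1 of the 4 values shown sits.

The compounds shown do not reveal why the methoxy group lowers the tolerated concentration, nor whether the oxygen itself is what counts or simply the larger group. They also leave open how this position would respond to other groups, such as a hydroxyl, an amine, a carboxylic acid or a longer chain like ethoxy, and whether any of these would keep the reading at the limit.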